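The source may hold more compounds than are shown below. What is called first, only, known or untested is meant among the compounds shown, and "the series" means these compounds.

Measured so far in a functional assay with Homo sapiens as the target; on this read-out higher numbers stand for weaker inhibition and lower numbers for stronger inhibition:
- compound 1 `CC(C)[C@H](NC(=O)COc1cccc2ccccc12)C(=O)N[C@@H](CC(=O)O)C(=O)COC(=O)c1c(Cl)cccc1Cl`: 11500 nM
- compound 2 `CC(C)[C@H](NC(=O)COc1cccc2ccccc12)C(=O)N[C@@H](CC(=O)O)C(=O)COc1ccccc1`: 11200 nM
- compound 3 `CC(C)[C@H](NC(=O)COc1cccc2ccccc12)C(=O)N[C@@H](CC(=O)O)C(=O)COc1cccc(C(F)(F)F)c1`: 16600 nM

In this assay compound 3, at 16600 nM, lies within the scatter of both other compounds. Compound 4 `CC(C)[C@H](NC(=O)COc1cccc2ccccc12)C(=O)N[C@@H](CC(=O)O)C(=O)COc1ccc(C(F)(F)F)cc1` carries 4-(trifluoromethyl)phenyl in place of 3-(trifluoromethyl)phenyl on an oxygen on a saturated carbon, with the same atoms joined differently (4-(trifluoromethyl)phenyl in place of 3-(trifluoromethyl)phenyl on an oxygen on a saturated carbon). For the measured compounds named here, no measured step moves the trifluoromethyl group itself, so the nearest evidence is indirect. Adding that group gave a 1.5-fold higher number from compound 2 to compound 3 (0.17 log units; within the scatter). Exchanging the whole group on the oxygen gave a 1.0-fold lower number from compound 1 to compound 2 (0.01 log units; within the scatter) and a 1.4-fold higher number from compound 1 to compound 3 (0.16 log units; within the scatter). Since even these larger changes stayed small, no shift beyond the scatter is expected. The estimated change is a 1.2-fold lower number from compound 3 to compound 4 (0.07 log units; within the scatter). Compound 4 is expected at 14000 nM, within an estimated range of 8000 nM to 25000 nM.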

Compound 4, half-maximal inhibitory concentration: 12300 nM
Compound 4: middle estimate off by 1.1-fold (0.06 log units), on the high side; the range from low to high includes it.
By their numbers in this assay, from the lowest: compounds 2, 1, 4 and 3 (each within the scatter of the next).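

In this assay, moving the trifluoromethyl group from 3-(trifluoromethyl)phenyl to 4-(trifluoromethyl)phenyl gives a 1.3-fold lower number from compound 3 to compound 4 (0.13 log units; within the scatter) and so provides the first direct test of where this group sits on the ring. Adding the group at this new place gives a 1.1-fold higher number from compound 2 to compound 4 (0.04 log units; within the scatter) and replacing (2,6-dichlorophenyl)carbonyl with 4-(trifluoromethyl)phenyl gives a 1.1-fold higher number from compound 1 to compound 4 (0.03 log units; within the scatter) and neither step leaves the scatter. No further measurement bears on this result. The compounds shown leave open whether an amine or a carboxylic acid on this ring would give a step beyond the scatter.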